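The source may hold more compounds than are shown below. What is called first, only, known or untested is meant among the compounds shown, and "the series" means these compounds.

Within the data shown here, compound 1, with the structure `COc1cc(-c2cc(/C=C/C(=O)c3ccc(Cl)c(Cl)c3)[nH]n2)cc(OC)c1OC`, is the weaker of the two compounds measured so far. In a functional assay on SW-620 cells (Homo sapiens) for inhibition, read by sulforhodamine B assay, with a stated time of 48 h (a lower number here means a stronger inhibitor of growth, a higher number a weaker inhibitor of growth), compound 1 gives 8630 nM, the highest number of the pair. Compound 2, with the structure `COc1ccc(-c2cc(/C=C/C(=O)c3cc(OC)c(OC)c(OC)c3)[nH]n2)cc1OC`, gives 1500 nM in this assay, a lower number that lies beyond the usual scatter, so compound 2 is the stronger inhibitor of growth of the two.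

The step under study leads from compound 1 to compound 3, whose structure is `COc1ccc(C(=O)/C=C/c2cc(-c3cc(OC)c(OC)c(OC)c3)n[nH]2)cc1OC`. The change is 3,4-dimethoxyphenyl in place of 3,4-dichlorophenyl on a carbonyl carbon. No such single change has been measured here, so the direction can only be inferred from the two numbers at hand. A shift toward a lower number, meaning stronger inhibition, seems the more likely outcome because compound 2, which carries only methoxy-bearing rings, gives 1500 nM, well below compound 1. Compound 3 is therefore expected to show a step of a 2.9-fold lower number from compound 1 to compound 3 (0.46 log units; beyond the scatter) in this assay. The estimate for compound 3 in this assay is 3000 nM, with a range from 1000 nM to 9000 nM.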

Compound 3, concentration for 50% growth inhibition: 1370 nM
Compound 3: middle estimate off by 2.2-fold (0.34 log units), on the high side, within the range that was stated.
By their numbers in this assay, from the lowest: compounds 3 and 2 (each within the scatter of the next); then compound 1.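

Compounds 1 and 2 differed in more than one place, so they could not isolate the group on the carbonyl carbon, but this pair can: in this assay, putting 3,4-dimethoxyphenyl in place of 3,4-dichlorophenyl gives a 6.3-fold lower number from compound 1 to compound 3 (0.80 log units; beyond the scatter). The group on this carbonyl carbon therefore affects growth inhibition in these cells, and with this core the change moves the number in the direction of stronger inhibition. The swap changes several things at once, with the hydrogen-bond acceptor count of the group going from 0 to 2 and its heavy-atom count also rising, and nothing measured here bears on why the number falls.

From the compounds shown here alone, it remains open whether the two methoxy groups are both needed, since a single methoxy group or a plain phenyl ring could be enough to give a similar number. Going by these compounds, it is also open how an amine or a carboxylic acid on this ring would compare, and whether this same swap would give a step of similar size on a different core.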